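The compounds below may be only part of what the source reports. "The series", "measured", "known", "first", "only" and "open" are said of these compounds alone.

Results in an ADME assay on HT-29 cells (Homo sapiens) for cytotoxicity, read by MTT assay, with a stated time of 72 h; on this read-out lower numbers stand for stronger inhibition and higher numbers for weaker inhibition:
Compound 1 `COc1ccc(C2=C(c3cc(OC)c(OC)c(OC)c3)C(=O)CC2O[SiH2]C(C)(C)C)cc1`: > 100 ug/mL
Compound 2 `COc1cc(C2=C(c3ccc(OCC(=O)O)cc3)C(O)CC2=O)cc(OC)c1OC`: "not determined" (no result reported)

Compound 2 has no number in this assay, so it offers no fixed point to start from. Compound 1 sits at > 100 ug/mL, which is a limit of the assay and not a number. The next compound is compound 3 `COc1ccc(C2=C(c3cc(OC)c(OC)c(OC)c3)C(=O)CC2O)cc1`, which has not been measured yet.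

The structural change runs (hydrogen in place of carboxy on a saturated chain carbon bound to an oxygen on an aromatic ring). Hydrogen stands in place of carboxy on a saturated chain carbon bound to an oxygen on an aromatic ring, so carboxymethoxy becomes methoxy. Within the data shown here, no measured step shows what such a change does here, so its size in this assay remains a loose guess. The expected direction is towards stronger inhibition, by an unknown margin. For compound 3 the estimated value is 10 ug/mL, with an expected range from 0.3 ug/mL to 100 ug/mL.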

Compound 3, half-maximal inhibitory concentration: 15 ug/mL
For compound 3 the middle estimate is 1.5-fold (0.18 log units) below the measured one; measured number inside the range.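

In this assay compound 1 stands at > 100 ug/mL, which is a limit of the assay and not a number. Placing a hydrogen atom on the oxygen on a saturated carbon, in place of the silicon-bearing group of 5 heavy atoms, gives an at least 6.6-fold lower number from compound 1 to compound 3 (0.82 log units; beyond the scatter), so a change at this position can move the read-out towards stronger inhibition. The step gives only a lower bound on the change and not its exact size, because one end of it is a limit: the limit of > 100 ug/mL in this assay, at which 1 of the 3 values shown sits.

From the compounds shown here alone, the step between compound 2 and compound 3 cannot be read, so the swap of carboxymethoxy for methoxy remains open. Going by these compounds, it is also open how a methyl ether or an acetyl ester on that oxygen, or an amine in its place, would compare.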